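A few compounds are considered here, and "the series" means these few. Any claim that something is new, unique, unknown or untested is made for them only; others in the source may bear on it.

Compound 1 `NC(=S)NNc1nncc2ccccc12`: 36 nM
Compound 2 `O=S(=O)(Nc1ccccn1)c1ccc(Nc2nncc3ccccc23)cc1`: 53 nM
Compound 3 `C(=C/c1ccccc1)\C(=N\Nc1nncc2ccccc12)c1ccccc1`: 2.2 nM

These three compounds share a core and were tested in a functional assay on MCF7 cells (Homo sapiens) for antiproliferative activity, read by sulforhodamine B assay, with a stated time of 72 h; on this read-out lower numbers stand for stronger inhibition and higher numbers for weaker inhibition. Among them, compound 2 has the highest number; compound 1 sits a short distance away, and the gap between the two is within the usual scatter, so nothing separates them. Compound 3 has a far lower number, beyond the scatter, and stands apart from both.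

Compound 4 `O=S(=O)(Nc1nccs1)c1ccc(Nc2nncc3ccccc23)cc1` has not yet been measured. It differs from compound 2 in one place: 1,3-thiazol-2-yl in place of pyridin-2-yl on a sulfonamide nitrogen. Within the data shown here, no measured pair shows the effect of such a swap, so there is no step to lean on. A five-membered aromatic ring takes the place of a six-membered aromatic ring on a sulfonamide nitrogen, and the rest of the molecule is unchanged. In this assay a step within the scatter is expected, in either direction. The expected 1.1-fold lower number from compound 2 to compound 4 (0.03 log units; within the scatter) is none beyond the scatter. Compound 4 is estimated at 50 nM, with a range from 15 nM to 170 nM.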

Compound 4, half-maximal inhibitory concentration: 55 nM
For compound 4 the middle estimate is 1.1-fold (0.04 log units) below the measured one; measured number inside the range.
By their numbers in this assay, from the lowest: compound 3; then compounds 1, 2 and 4 (each within the scatter of the next).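

In this assay, among these compounds, putting 1,3-thiazol-2-yl in place of pyridin-2-yl on the sulfonamide nitrogen gives a 1.0-fold higher number from compound 2 to compound 4 (0.02 log units; within the scatter) and so provides the first measured pair that differs in one place. At this position, the two groups cannot be told apart in this read-out. A five-membered aromatic ring with two hetero atoms and a six-membered aromatic ring with one hetero atom therefore give matching results here, at least for this one swap. No measurement shown explains this match. On these data alone, whether an aromatic ring is needed on the sulfonamide nitrogen remains open, as a methyl group or a simple amine-bearing chain in this place could behave differently. As far as these compounds go, how a carboxylic acid on the pyridin-2-yl or 1,3-thiazol-2-yl ring would affect the number also remains unknown.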